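The source may report more compounds than this note shows. Statements on the series, on what has been measured and on what is new or still open speak of the compounds shown alone.

Values measured so far in a functional assay on MES-SA cells (Homo sapiens) for inhibition, with a stated time of 72 h, in the presence of a further agent that is not named here; a lower number here means a stronger inhibitor, a higher number a weaker inhibitor
- compound 1 `Oc1c(CN2CCCC2)cc(Br)c2cccnc12` gives 4470 nM
- compound 2 `CCOCc1cc(CN2CCCC2)c(O)c2ncccc12` gives 8710 nM

Among the measured compounds shown here, compound 2 stands within the scatter of compound 1, the only other compound measured. For the measured compounds named here, the one measured step, a 1.9-fold higher number from compound 1 to compound 2 (0.29 log units; within the scatter), is ethoxymethyl in place of bromo on an aromatic carbon, and it stays within the scatter.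

Compound 3 `CCOCc1cc(CN2CCCCC2)c(O)c2ncccc12` keeps the ethoxymethyl of compound 2 and carries piperidin-1-yl in place of pyrrolidin-1-yl on a saturated chain carbon bound to an aromatic carbon. Going by the values given here, no measured step touches this group, since compound 1 and compound 2 both carry pyrrolidin-1-yl. The data therefore give no direct guide, and no step beyond the scatter is expected in this assay, in either direction. The expected step is a 1.1-fold lower number from compound 2 to compound 3 (0.04 log units; within the scatter). Compound 3 is estimated at 8000 nM, with an expected range from 3000 nM to 20000 nM.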

Compound 3, half-maximal inhibitory concentration: 9120 nM
Beside the measured number, compound 3's estimate is 1.1-fold (0.06 log units) below it, within the range that was stated.
By their numbers in this assay, from the lowest: compounds 1, 2 and 3 (each within the scatter of the next, the first and the last beyond it).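

In this assay, among the compounds shown here, the step at this position is a 1.0-fold higher number from compound 2 to compound 3 (0.02 log units; within the scatter), the first reading of any change to this group: piperidin-1-yl in place of pyrrolidin-1-yl on a saturated chain carbon bound to an aromatic carbon. Going from the five-membered to the six-membered ring therefore moves the number no further than the scatter, and this holds for the ethoxymethyl series only. Nothing is available to explain this result.

The compounds shown leave open whether the same swap would also stay within the scatter with bromo on the aromatic carbon, as in compound 1. They also leave open what a morpholin-4-yl ring or an open-chain dimethylamino group on the same saturated chain carbon would do to the number.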